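From dichlorophenyl to trifluoromethylphenyl on the carbonyl

The compounds below may be only part of what the source reports. "The series", "measured", "known", "first", "only" and "open" are said of these compounds alone.

Compound 2 `COc1ccc(-c2sc(N)c(C(=O)c3ccc(Cl)c(Cl)c3)c2CC(C)(C)C)cc1` gives 1% in an assay on CHO cells for displacement of a labelled ligand from adenosine receptor A1 (Homo sapiens), read by scintillation counting, tested at 10 uM (a lower number here means less inhibition, a higher number more inhibition at the concentration tested (going by the name of the read-out)), a value level with that of compound 1 `COc1ccc(-c2sc(N)c(C(=O)c3ccc(Cl)cc3)c2CC(C)(C)C)cc1`, which gives 1%. Among the compounds with values here, the single measured step, no change at the digits printed from compound 1 to compound 2 (within the scatter), came from chloro in place of hydrogen on an aromatic carbon and left the read-out unchanged within the scatter; at the concentration tested, neither compound displaces much of the labelled ligand.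

Compound 3 `COc1ccc(-c2sc(N)c(C(=O)c3cccc(C(F)(F)F)c3)c2CC(C)(C)C)cc1` has not yet been measured. It differs from compound 2 in one place: 3-(trifluoromethyl)phenyl in place of 3,4-dichlorophenyl on a carbonyl carbon. Within the data shown here, the one measured step bears on this change only loosely, since it altered the same ring on the carbonyl carbon but with a different group. That step was flat, and nothing seen so far on this ring has moved the read-out away from its low level.

On this basis no step beyond the scatter is expected. The value of compound 3 in this assay is estimated at 3%, within a range from -8% to 15%. The expected step is a number 2 percentage points higher from compound 2 to compound 3 (within the scatter).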

Compound 3, a percentage reported as inhibition, at one concentration (the size of the read-out at that concentration, not a potency): 2%
Compound 3: middle estimate off by 1 percentage points, on the high side, and the stated range covers the measured number.
By their numbers in this assay, from the lowest: compounds 1, 2 and 3 (each within the scatter of the next).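

In this assay, putting 3-(trifluoromethyl)phenyl in place of 3,4-dichlorophenyl on the carbonyl carbon gives a number 1 percentage points higher from compound 2 to compound 3 (within the scatter), so the read-out stays level even when the ring carries no chlorine at all. Set against the simpler 4-chlorophenyl, the same group gives a number 1 percentage points higher from compound 1 to compound 3 (within the scatter), which means that the three rings on this carbonyl carbon cannot be told apart in this measurement, and the earlier chloro step alone could not show that this flatness extends beyond chlorine-bearing rings. No measurement at hand offers an explanation for this flat result, so the reason for it remains unknown.

All three compounds sit at the same low level, so the data do not show whether any group on this ring can raise the read-out, for example an amine or a carboxylic acid on the ring, or a plain alkyl chain in place of the ring. Changes elsewhere on the shared core also remain open, and so does whether any compound would give a stronger effect at another concentration, since a read-out this low at a single concentration cannot rank these compounds.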